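Macrophage cytotoxicity: from compound 2 to compound 3

A few compounds are considered here, and "the series" means these few. Any claim that something is new, unique, unknown or untested is made for them only; others in the source may bear on it.

In an ADME assay on cells (Macrophage, Mus musculus) for cytotoxicity, read by resazurin assay, with a stated time of 3 days (on this read-out higher numbers stand for weaker inhibition and lower numbers for stronger inhibition), compound 1 `O=C(Nc1ccccc1)c1ccc(NC(=O)c2cc(Cl)ccc2O)cc1` gives > 60000 nM, which is a limit of the assay rather than a number. Compound 2 `O=C(Nc1ccc(S(=O)(=O)Nc2ccccc2)cc1)c1cc(Cl)ccc1O` gives > 60000 nM, likewise a limit. Compound 2 therefore stands at the limit of > 60000 nM in this assay, at which 2 of the 2 values shown sit, and no order between the two measured compounds can be drawn. Compound 3 `Cc1cc(NS(=O)(=O)c2ccc(NC(=O)c3cc(Cl)ccc3O)cc2)no1` differs from compound 2 by 5-methyl-1,2-oxazol-3-yl in place of phenyl on a sulfonamide nitrogen. Going by the values given here, no measured step covers this change, so no shift beyond the usual scatter is expected. The step expected in this assay is a step that the limit leaves unreadable from compound 2 to compound 3. For compound 3 the estimate is 80000 nM, in the range 30000 nM to 300000 nM, most probably reported again only as a limit.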

Compound 3, half-maximal inhibitory concentration: > 60000 nM
Compound 3: only a limit was reported (the forecaster's own chance of this, stated with the estimate: 85%); the middle value is on the limit's open side.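

No step can be read between compound 2 and compound 3, since both values are only limits: the limit of > 60000 nM in this assay, at which 3 of the 3 values shown sit.

Still open is whether 5-methyl-1,2-oxazol-3-yl in place of phenyl changes macrophage cytotoxicity at all; none of the compounds shown gives a number.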